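Methyl for hydrogen on the aryl ether chain

A few compounds are considered here, and "the series" means these few. Any claim that something is new, unique, unknown or untested is made for them only; others in the source may bear on it.

Measured so far in an assay for displacement of a labelled ligand from Apoptosis regulator Bcl-2 (Homo sapiens), read by fluorescence polarization, with a stated time of 30 min; on this read-out lower numbers stand for stronger inhibition and higher numbers for weaker inhibition:
compound 1, `CCOc1ccc(-c2cc(C(=O)O)nn2-c2ccccc2)cc1`, gives 6090 nM;
compound 2, `CC(C)Oc1ccc(-c2cc(C(=O)O)nn2-c2ccccc2)cc1`, gives 7000 nM;
compound 3, `CCOc1ccc(-c2c(NC(=O)c3ccc(OC(C)C)cc3)c(C(=O)O)nn2-c2ccc(Oc3ccccc3)cc2)cc1`, gives 28 nM.

Compound 1 and compound 2 share a core and differ only by methyl in place of hydrogen on a saturated chain carbon bound to an oxygen on an aromatic ring and a saturated chain carbon. The step is a 1.1-fold higher number from compound 1 to compound 2 (0.06 log units; within the scatter), so the two values cannot be told apart. Compound 3 sits on a larger core; how it differs from compound 1 is not broken down here. Its value stands far below those of compound 1 and compound 2, and the gap to each of them is beyond the usual scatter, so compound 3 is the strongest of the three in this assay.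

Compound 4, `CC(C)Oc1ccc(C(=O)Nc2c(C(=O)O)nn(-c3ccc(Oc4ccccc4)cc3)c2-c2ccc(OC(C)C)cc2)cc1`, has not yet been measured. Among the compounds with values here, it differs from compound 3 by methyl in place of hydrogen on a saturated chain carbon bound to an oxygen on an aromatic ring and a saturated chain carbon, which is the same change, at the same place, as the one from compound 1 to compound 2. Within the data shown here, the only guide is that single measured pair, and it showed no movement. The step from compound 3 to compound 4 is therefore expected to be about a 1.1-fold higher number from compound 3 to compound 4 (0.03 log units; within the scatter). For compound 4 the estimate in this assay is 30 nM, with a likely range from 12 nM to 75 nM. On these data alone, this rests on one pair on a smaller core, and whether the same change behaves alike on the core of compound 3 is untested.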

Compound 4, inhibition constant: 140 nM
Compound 4: middle estimate off by 4.7-fold (0.67 log units), on the low side; measured number outside the range, above it.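

In this assay, the change from 4-ethoxyphenyl to 4-isopropoxyphenyl on the core of compound 3 gives a 5.0-fold higher number from compound 3 to compound 4 (0.70 log units; beyond the scatter) and is therefore a real loss on this core. These two pairs show only that the added methyl does not behave alike on both cores, and they do not identify which of the several differences between the two cores goes with the larger step. With one pair per core, they give no rule for any other core in the series, and the step on the smaller core proved a poor guide to the step on the larger one: the same change on two cores in this assay, a 1.1-fold higher number (0.06 log units; within the scatter) from compound 1 to compound 2 and a 5.0-fold higher number (0.70 log units; beyond the scatter) from compound 3 to compound 4, 4.4-fold (0.64 log units) apart, beyond the scatter of two such steps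

Within the data shown here, it remains open whether the phenyl-bearing amide, the phenoxy group, or both together separate the behaviour of the two cores, a question that intermediate compounds carrying only one of these groups could address. On these data alone, it is also open how the core of compound 3 would respond at the same place to a methoxy group, a longer chain such as propoxy, or a cyclopropylmethoxy group, and so whether the loss continues with further growth of the ether chain or is particular to isopropoxy.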